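The source may hold more compounds than are shown below. What is called first, only, known or untested is meant among the compounds shown, and "the series" means these compounds.

Working notes on the series. Compound 2 `Cc1ccc(OCCCCOc2ccc(C(=O)CC(C)(C)C)c(O)c2C)cc1C(=O)O` gives the highest number of the three in an assay for positive allosteric modulation of metabotropic glutamate receptor 2 (Rattus norvegicus) (a higher number here means that more compound is needed for the effect, a lower number that less compound is needed), with compound 2 at 210 nM; compound 3 `COc1cc(OCCCCOc2ccc(C(=O)CC(C)(C)C)c(O)c2C)cc(C(=O)O)c1` gives 102 nM and compound 1 `Cc1c(OCCCCOc2ccc(Cl)c(C(=O)O)c2)ccc(C(=O)CC(C)(C)C)c1O` gives 87 nM. For the measured compounds named here, the only measured single-point step is a 2.4-fold higher number from compound 1 to compound 2 (0.38 log units; beyond the scatter). Compound 4 `COc1ccc(OCCCCOc2ccc(C(=O)CC(C)(C)C)c(O)c2C)cc1` differs from compound 2 by 4-methoxyphenyl in place of 3-carboxy-4-methylphenyl on an oxygen on a saturated carbon. Going by the values given here, no measured step covers this exchange: all three measured compounds carry the carboxy group, and the step from compound 1 to compound 2 concerns only the chloro-to-methyl swap. Among the compounds with values here, the expectation for compound 4 therefore rests on no direct precedent and is given a wide range, with the estimated step of a 3.3-fold higher number from compound 2 to compound 4 (0.52 log units; beyond the scatter). Compound 4 is estimated at 700 nM, within 150 nM to 4000 nM.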

Compound 4, half-maximal effective concentration: > 10000 nM
Compound 4 gave a limit, no number; the forecaster's own chance of this, stated with the estimate: 15%; at least 14-fold (1.15 log units) between middle value and limit.
By their numbers in this assay, from the lowest: compounds 1 and 3 (each within the scatter of the next); then compound 2. At a limit, above all of these: compound 4.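

In this assay, compound 4 gives a limit and not a number: the limit of > 10000 nM in this assay, at which 1 of the 4 values shown sits.

Exchanging the aryl group on this oxygen is a large step, read against the limit as an at least 47-fold higher number from compound 2 to compound 4 (1.67 log units; beyond the scatter) and as an at least 110-fold higher number from compound 1 to compound 4 (2.06 log units; beyond the scatter). The earlier compounds shown here all keep the carboxy group and differ only in its companion substituent, whereas these steps show that 4-methoxyphenyl at this place does not retain a measurable number.

The exchange changes the carboxy group, the methoxy group and the methyl or chloro group together, so the loss cannot be assigned to one of them. As far as these compounds go, whether an amide or a tetrazole in place of the carboxy group would keep a measurable number stays open.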